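Demethylating the piperazine in a cytotoxicity series

The source may report more compounds than this note shows. Statements on the series, on what has been measured and on what is new or still open speak of the compounds shown alone.

The measured compounds are:
compound 1, `CN1CCN(c2ccc(/C=C3/SC(N(c4ccccc4)c4ccccc4)=NC3=O)cc2)CC1`
compound 2, `O=C1N=C(N(c2ccccc2)c2ccccc2)S/C1=C/c1ccc(N2CCNCC2)cc1`
compound 3, `CN1CCN(c2ccc(/C=C3/SC(N(C)c4ccccc4)=NC3=O)cc2)CC1`

In an ADME assay on cells (Homo sapiens) for cytotoxicity, read by sulforhodamine B assay, with a stated time of 48 h (a higher number here means that more compound is needed for the effect, a lower number that less compound is needed), compound 1 gives only a limit of the assay, > 100000 nM. Compound 2 likewise gives only a limit in this assay, > 100000 nM. Compound 3 too gives only a limit in this assay, > 100000 nM. All three sit at the limit of > 100000 nM in this assay, at which 3 of the 3 values shown sit, so no ordering among them can be read.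

Compound 2 arises from compound 1 by hydrogen in place of methyl on an amine nitrogen in a ring; the step that the two limits leave unreadable from compound 1 to compound 2 cannot be sized. Compound 3 differs from compound 1 in its core by methyl in place of phenyl on a nitrogen on an aromatic ring, and the step that the two limits leave unreadable from compound 1 to compound 3 is equally unreadable.

The unmeasured compound 4, `CN(C1=NC(=O)/C(=C\c2ccc(N3CCNCC3)cc2)S1)c1ccccc1`, is obtained from compound 3 by hydrogen in place of methyl on an amine nitrogen in a ring. This is the same change as that from compound 1 to compound 2, made on the core of compound 3 instead; the description of the place is identical word for word in both cases.

Since the step from compound 1 to compound 2 stayed within limits, and compound 3 itself gives only a limit, the expectation for the step that the limit leaves unreadable from compound 3 to compound 4 is that it too remains unreadable. Compound 4 is therefore estimated at 150000 nM, with a likely range of 60000 nM to 400000 nM, most probably again reported only as a limit.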

Compound 4, half-maximal effective concentration: > 100000 nM
Compound 4 was reported as a limit; the forecaster's own chance of this, stated with the estimate: 85%; the middle value is on the limit's open side.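

Compound 4 gives only a limit in this assay, > 100000 nM. With compound 2 and compound 3 also at a limit, neither step to compound 4 can be read, and all four compounds sit together: the limit of > 100000 nM in this assay, at which 4 of the 4 values shown sit.

The compounds shown leave open whether either change, hydrogen in place of methyl or methyl in place of phenyl, alters the value in this assay at all.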